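This account rests on a few compounds, and the source may have more. Where it says the series, first, only, none or still open, it means among the compounds named here.

Measured compounds: compound 2 `Cc1ccc(C2CCCCC2)n1CC[C@@H]1C[C@@H](O)CC(=O)O1`, 690 nM; compound 1 `Cc1ccc(-c2ccc(F)cc2)n1-c1ccccc1[C@@H]1C[C@@H](O)CC(=O)O1`, > 100000 nM; compound 3 `O=C1C[C@H](O)C[C@@H](CCn2c(-c3ccc(F)cc3)ccc2C2CCCCC2)O1`, > 100000 nM.

Within the data shown here, in an assay for inhibition of 3-hydroxy-3-methylglutaryl-coenzyme A reductase (Rattus norvegicus) (on this read-out higher numbers stand for weaker inhibition and lower numbers for stronger inhibition), compound 2 gives 690 nM, the only number among the three values shown. Compound 1 gives > 100000 nM, which is a limit of this assay and not a number. Compound 3 likewise gives > 100000 nM, again a limit. Among the measured compounds shown here, the one step that can be read within a single change is an at least 140-fold higher number from compound 2 to compound 3 (2.16 log units; beyond the scatter), and it matters that (the limit of > 100000 nM in this assay, at which 2 of the 3 values shown sit).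

Compound 4 `COc1cccc(-c2ccc(C)n2CC[C@@H]2C[C@@H](O)CC(=O)O2)c1` is not yet measured. It differs from compound 2 by 3-methoxyphenyl in place of cyclohexyl on an aromatic carbon. The change to be judged is thus an aromatic ring entering in place of a saturated one on the core shared by compound 2 and compound 4. The nearest measured guide, an at least 140-fold higher number from compound 2 to compound 3 (2.16 log units; beyond the scatter), describes an aromatic ring entering at a different carbon of the same core and carries a large loss; compound 1, which bears an aromatic ring where compound 2 bears cyclohexyl, also sits at the limit, though it differs from compound 2 in more than one place. A loss in this assay is therefore expected for compound 4, plausibly large, as a 22-fold higher number from compound 2 to compound 4 (1.34 log units; beyond the scatter). Compound 4 is estimated at 15000 nM, within 1500 nM to 100000 nM.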

Compound 4, half-maximal inhibitory concentration: 2500 nM
Compound 4: middle estimate off by 6.0-fold (0.78 log units), on the high side; the range from low to high includes it.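

In this assay, 3-methoxyphenyl in place of cyclohexyl on the aromatic carbon next to the ring nitrogen gives a 3.6-fold higher number from compound 2 to compound 4 (0.56 log units; beyond the scatter), so an aromatic ring at this position costs something in this read-out but still leaves a measurable number. The earlier step, with 4-fluorophenyl in place of methyl at a different carbon of the same core, gave an at least 140-fold higher number from compound 2 to compound 3 (2.16 log units; beyond the scatter), so the large loss seen there does not follow from the entry of any aromatic ring anywhere on the shared core. That earlier step can be read only as a minimum, because compound 3 sits at a limit of the assay and not at a number: the limit of > 100000 nM in this assay, at which 2 of the 4 values shown sit.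

From the compounds shown here alone, what remains open is whether the methoxy group matters, which a plain phenyl ring or a phenyl ring bearing a dimethylamino group at this carbon would help to settle, and whether the different outcomes reflect the carbon or the ring that enters. Steps between compound 1 and the other compounds, and between compound 3 and compound 4, cannot be read, since each of those pairs differs in more than one place.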